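Losing the hydroxylated chain end on the shared core

The source may report more compounds than this note shows. Statements on the series, on what has been measured and on what is new or still open speak of the compounds shown alone.

Values in a functional assay on FM3A cells (Mus musculus) for cytotoxicity; on this read-out lower numbers stand for an effect already at smaller amounts and higher numbers for an effect only at larger amounts of compound:
- compound 1 `CCCCOOC1(OOC)CCCCCCCCCCC1`: 20000 nM
- compound 2 `COOC1(OOCCCCCCO)CCCCCCCCCCC1`: 1600 nM
- compound 3 `C=CCCOOC1(OOC)CCCCCCCCCCC1`: not yet measured

Among the measured compounds shown here, compound 2 holds the lower of the two numbers so far, at 1600 nM. Only compound 1 stands beside it, and the gap between them is beyond the scatter. Compound 3 differs from compound 2 as follows: vinyl in place of 4-hydroxybutyl on a saturated chain carbon, two bonds along the chain from an oxygen.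

For the measured compounds named here, one measured step bears on this change: a 13-fold lower number from compound 1 to compound 2 (1.10 log units; beyond the scatter). It came with 2-hydroxyethyl in place of hydrogen on a saturated chain carbon, four bonds along the chain from an oxygen. Compound 3 loses the hydroxylated chain end again, so a clear move back toward compound 1 at 20000 nM is expected in this assay. On these data alone, neither measured compound carries vinyl, so what that group adds is unknown.

The expected change is a 7.5-fold higher number from compound 2 to compound 3 (0.88 log units; beyond the scatter), larger than the scatter. For compound 3 the estimated value is 12000 nM, with an expected range from 4000 nM to 30000 nM.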

Compound 3, half-maximal effective concentration: 6000 nM
Estimate against measurement, compound 3: 2.0-fold (0.30 log units) above; the measured number falls inside the stated range.
By their numbers in this assay, from the lowest: compound 2; then compound 3; then compound 1.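

Replacing 4-hydroxybutyl with vinyl in this assay gives a 3.8-fold higher number from compound 2 to compound 3 (0.57 log units; beyond the scatter) and so gives up part of what the hydroxylated chain end had gained, but the number does not go all the way back. Set against the ethyl group at the same place, vinyl gives a 3.3-fold lower number from compound 1 to compound 3 (0.52 log units; beyond the scatter) even though neither compound carries a hydroxyl group. The hydroxylated chain end of compound 2 is therefore not the only feature at this position that separates a compound from compound 1, and compound 3 sits at an intermediate level with its unsaturated chain end; nothing available here explains either shift.

The compounds shown do not settle whether an amine or a carboxylic acid at the chain end would act as the hydroxyl group of compound 2 does. They also leave open whether a longer chain ending in vinyl, with no hydroxyl group, would stay at the level of compound 3 or come closer to compound 2.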